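The compounds below may be only part of what the source reports. "The series", "measured", "known", "first", "only" and "open" are said of these compounds alone.

Within the data shown here, compound 1 `CC(C)c1ccc(S(=O)(=O)NCCCCCCNCc2ccc(Br)cc2)cc1` is one of two compounds measured in a functional assay on MIA PaCa-2 cells (Homo sapiens) for inhibition, read by MTT assay, with a stated time of 72 h; a higher number here means a weaker inhibitor of growth, a lower number a stronger inhibitor of growth. In this assay compound 1 gives 5730 nM. Among the measured compounds shown here, the only comparison available is compound 2 `O=S(=O)(NCCCCCCNCc1ccc(Br)cc1)c1ccc2ccsc2c1`, which in this assay gives 6000 nM; the single measured step, a 1.0-fold higher number from compound 1 to compound 2 (0.02 log units; within the scatter), changes the group on the sulfonyl sulfur and leaves the number essentially unchanged. Compound 1 and compound 2 therefore sit within the scatter of each other, and neither can be called the stronger or weaker growth inhibitor.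

Compound 3 `CC(C)(C)c1ccc(S(=O)(=O)NCCCCCCNCc2ccc(Br)cc2)cc1` is not yet measured. It differs from compound 1 by methyl in place of hydrogen on a saturated chain carbon bound to an aromatic carbon and two saturated chain carbons. For the measured compounds named here, no measured step touches this part of the molecule: the one step known alters the aromatic group on the sulfonyl sulfur as a whole, not the branching of the chain attached to it. With nothing pointing either way, the expectation is a step in this assay no larger than the scatter, so compound 3 is estimated at 5700 nM, within a range of 2800 nM to 11500 nM. That amounts to an expected step of a 1.0-fold lower number from compound 1 to compound 3 (0.00 log units; within the scatter).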

Compound 3, concentration for 50% growth inhibition: 2970 nM
The estimate for compound 3 lay 1.9-fold (0.28 log units) above the measured number; measured number inside the range.
By their numbers in this assay, from the lowest: compounds 3, 1 and 2 (each within the scatter of the next, the first and the last beyond it).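

Changing isopropyl to tert-butyl adds one methyl on a saturated chain carbon bound to an aromatic carbon and two saturated chain carbons, and in this assay this gives a 1.9-fold lower number from compound 1 to compound 3 (0.29 log units; within the scatter) and so cannot be read as a real gain or loss. The earlier step replaced the whole aromatic group on the sulfonyl sulfur, whereas this one tests only the branching of the alkyl group, and the extra carbon is tolerated here, with growth inhibition remaining in the same range. No supporting measurement comes with this result to explain the size of the step.

The compounds shown leave open what other groups at this place would do, such as a smaller ethyl, a cyclopropyl ring or a hydroxyl on the chain carbon. As far as these compounds go, they also keep the rest of the molecule fixed, so the effect of a longer chain, or of chlorine in place of the bromine, remains unknown.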